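The source may hold more compounds than are shown below. What is called first, only, known or untested is meant among the compounds shown, and "the series" means these compounds.

In an unclassified assay for pharmacokinetics, read by NMR, tested at 2 mg/mL (a higher number here means that the compound lasts longer, a lower number that the compound disappears faster), compound 1 `COc1ccc(/N=N\c2ccc(F)c(C(=O)Nc3cnc4[nH]nc(OC)c4c3)c2F)cc1` gives > 10 h as a limit of the assay and not a number. Compound 2 `COc1n[nH]c2ncc(NC(=O)c3c(F)ccc(/N=N\c4ccccc4F)c3F)cc12` gives > 20 h and also stands only at a limit of the assay. For the measured compounds named here, the one measured change on the double-bonded nitrogen is a step that the two limits leave unreadable from compound 1 to compound 2 with 2-fluorophenyl in place of 4-methoxyphenyl. Compound 3 `COc1n[nH]c2ncc(NC(=O)c3c(F)ccc(/N=N\c4ccc(C)cc4)c3F)cc12` differs from compound 2 at this same place, 4-methylphenyl in place of 2-fluorophenyl on a double-bonded nitrogen with 4-methylphenyl in place of 2-fluorophenyl. Since a step that the two limits leave unreadable from compound 1 to compound 2 gives no size to carry over, no step beyond the scatter and no direction is expected in this assay for this change. The estimate gives an expected step that the limit leaves unreadable from compound 2 to compound 3. The half-life of compound 3 is estimated at 25 h as the middle value. The expected range for compound 3 runs from 10 h to 60 h in this estimate.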

Compound 3, half-life: > 20 h
Compound 3: a limit, no number; the forecaster's own chance of this, stated with the estimate: 60%; the middle value is on the limit's open side.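

In this assay compound 3 gives > 20 h, a limit of the assay and not a number. No new step can be read from compound 1 or compound 2 to compound 3. Going by these compounds, the true half-lives of compound 1, compound 2 and compound 3, and their order, remain open.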